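Methoxy for chloro on the shared core: compound 4

This account rests on a few compounds, and the source may have more. Where it says the series, first, only, none or still open, it means among the compounds named here.

Measured so far:
compound 1 `COc1ccc2nc(NC(=O)c3cn(-c4ccccc4)nc3-c3ccc(Cl)cc3)sc2c1` — 31400 nM
compound 2 `COc1ccc(-c2nn(-c3ccccc3)cc2C(=O)Nc2nc3ccc(F)cc3s2)cc1` — 7560 nM
compound 3 `COc1ccc(-c2nn(-c3ccccc3)cc2C(=O)Nc2nc3ccc(Cl)cc3s2)cc1` — 4710 nM

In a functional assay on A549 cells (Homo sapiens) for cytotoxicity, read by MTT assay, with a stated time of 72 h (a lower number here means a stronger inhibitor, a higher number a weaker inhibitor), compound 3 gives the lowest of the three numbers; compound 2 sits within the scatter of it, compound 1 lies beyond it. Compound 4 `COc1ccc(-c2nn(-c3ccccc3)cc2C(=O)Nc2nc3ccc(OC)cc3s2)cc1` differs from compound 3 by methoxy in place of chloro on an aromatic carbon. For the measured compounds named here, the only single-point step in the set is a 1.6-fold lower number from compound 2 to compound 3 (0.21 log units; within the scatter), one halogen exchanged for another at the same carbon; it says nothing about a methoxy there. Compound 1 carries a methoxy at that carbon and gives the highest number, but it also differs from compound 3 on the other ring, so its value is a hint only. Compound 4 is therefore expected to give a somewhat higher number, 9000 nM (range 3000 nM to 35000 nM). The expected step of a 1.9-fold higher number from compound 3 to compound 4 (0.28 log units; within the scatter) is loosely held, resting on compound 1 and its 31400 nM alone.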

Compound 4, half-maximal inhibitory concentration: 18900 nM
The estimate for compound 4 lay 2.1-fold (0.32 log units) below the measured number; the range from low to high includes it.
By their numbers in this assay, from the lowest: compounds 3 and 2 (each within the scatter of the next); then compounds 4 and 1 (each within the scatter of the next).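

In this assay, going from 6-chloro-1,3-benzothiazol-2-yl to 6-methoxy-1,3-benzothiazol-2-yl gives a 4.0-fold higher number from compound 3 to compound 4 (0.60 log units; beyond the scatter), and methoxy in place of fluoro at the same carbon gives a 2.5-fold higher number from compound 2 to compound 4 (0.40 log units; beyond the scatter). This carbon therefore responds to methoxy, although the two halogens there lie within the scatter of each other. With methoxy held at this carbon, methoxy in place of chloro on the other ring gives a 1.7-fold lower number from compound 1 to compound 4 (0.22 log units; within the scatter), so no difference is resolved for that change.

No measurement here accounts for these steps. On these data alone, how an amine or a carboxylic acid at this carbon would read remains open.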